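Removing One Chloro from a Dichloro Inhibitor

The source may report more compounds than this note shows. Statements on the series, on what has been measured and on what is new or still open speak of the compounds shown alone.

Measured so far:
Compound 1, `CC1(C)N=C(N)N=C(N)N1c1ccc(OCc2ccccc2C(=O)Nc2ccc(S(=O)(=O)F)cc2)c(Cl)c1`, 7.24
Compound 2, `CC1(C)N=C(N)N=C(N)N1c1cc(Cl)c(OCC(=O)Nc2ccc(S(=O)(=O)F)cc2)c(Cl)c1`, 7.74
Compound 3, `CC1(C)N=C(N)N=C(N)N1c1ccc(OCCCC(=O)Nc2ccc(S(=O)(=O)F)cc2)c(Cl)c1`, 7.15

In an assay on isolated protein for inhibition of Dihydrofolate reductase (Mus musculus) (a lower number here means a less potent compound, a higher number a more potent compound, by a factor of ten per unit of this negative logarithm), compound 2 gives the highest of the three numbers, standing beyond the scatter above both compound 1 and compound 3. Compound 4, `CC1(C)N=C(N)N=C(N)N1c1ccc(OCC(=O)Nc2ccc(S(=O)(=O)F)cc2)c(Cl)c1`, is not yet measured. It differs from compound 2 by one change: hydrogen in place of chloro on an aromatic carbon. Going by the values given here, compound 2 is the only one of the three measured with two chloro groups; compound 1 and compound 3 carry one each and sit lower, though their linkers also differ, so no clean step isolates this change. A moderate downward step is expected for compound 4, a number 0.34 log units lower from compound 2 to compound 4 (beyond the scatter). The estimate for compound 4 in this assay is 7.4, within 7 to 7.9.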

Compound 4, logarithm of the reciprocal of the active concentration, log(1/C): 7.43
Compound 4: middle estimate off by 0.03 log units, on the low side; measured number inside the range.
By their numbers in this assay, from the lowest: compounds 3, 1 and 4 (each within the scatter of the next); then compound 2.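

Going by these compounds alone, with the linker held the same, this assay gives the first clean reading of this change: hydrogen in place of chloro brings a number 0.31 log units lower from compound 2 to compound 4 (beyond the scatter) on this one aromatic carbon. Within the data shown here, the chloro ortho to a large group therefore carries a real but limited share of the potency of compound 2, a share the differing linkers of the earlier compounds could not separate out.

On these data alone, whether a fluoro, bromo or methyl group on the same carbon would match chloro stays open, as does whether this step holds with other linkers. No measurement shown here explains the step.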